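The source may report more compounds than this note shows. Statements on the series, on what has been measured and on what is new or still open speak of the compounds shown alone.

Measured so far in a functional assay on the whole organism (strain Wistar albino) for inhibition, with Rattus norvegicus as the target, read by paw edema, with stated times of 1 h and 4 h, at a dose of 40 mg/kg by the oral route; on this read-out higher numbers stand for more inhibition at the one dose given (going by the name of the read-out) and lower numbers for less inhibition:
compound 1 `COc1ccc(N2C(=O)CSC2c2sc(Cc3ccc(Cl)cc3)nc2C)cc1`: 55.9%
compound 2 `Cc1nc(-c2ccc(Cl)cc2)sc1C1SCC(=O)N1c1ccc(Cl)cc1`: 43.2%

Compound 2 stands lowest of the two numbers; its nearest neighbour is compound 1, whose reading is higher by a gap beyond the scatter. The two differ in more than one place, so no single step can be read from them.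

Compound 3 `Cc1nc(Cc2ccc(Cl)cc2)sc1C1SCC(=O)N1c1ccc(Cl)cc1` is not yet measured. It arises from compound 2 by one change: 4-chlorobenzyl in place of 4-chlorophenyl on an aromatic carbon. The group that leaves is 4-chlorophenyl and the one that enters is 4-chlorobenzyl, on an aromatic carbon of a five-membered aromatic ring with 1 nitrogen and 1 sulfur. Compound 3 thus carries the same 4-chlorobenzyl as compound 1 while keeping the other group of compound 2. Within the data shown here, no measured pair shows this change alone, so its size cannot be read from data. Only the fact that compound 1 gives 55.9% while compound 2 gives 43.2% hints at a direction. The step expected in this assay is a modest rise, a number 5.8 percentage points higher from compound 2 to compound 3 (within the scatter), with none beyond the scatter fully possible. Compound 3 is therefore estimated at 49%, within a range from 38% to 60%.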

Compound 3, a percentage reported as inhibition, in the whole organism at one dose (the size of the read-out at that dose, not a potency): 53.9%
Beside the measured number, compound 3's estimate is 4.9 percentage points below it; low and high end bracket the measured number.
By their numbers in this assay, from the lowest: compound 2; then compounds 3 and 1 (each within the scatter of the next).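

In this assay the exchange at this position, on an aromatic carbon next to the ring nitrogen and next to the ring sulfur, now has a measured size: 4-chlorobenzyl in place of 4-chlorophenyl gives a number 10.7 percentage points higher from compound 2 to compound 3 (beyond the scatter) and so registers as a real step at this one dose. With 4-chlorobenzyl held at this position, the exchange of methoxy for chloro on the other aromatic ring gives a number 2 percentage points lower from compound 1 to compound 3 (within the scatter), so that change does not separate the two compounds in this read-out. No measurement bears on why either step has the size it has.

The compounds shown leave open whether the rise is specific to 4-chlorobenzyl or would also appear with a longer chain such as 2-(4-chlorophenyl)ethyl, or with an amine linking the chlorophenyl ring to the core. They also leave open whether methoxy and chloro would stay as close together with 4-chlorophenyl at this position, and how a carboxylic acid on that ring would read in this assay.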